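The source may hold more compounds than are shown below. What is called first, only, known or untested is meant among the compounds shown, and "the series" means these compounds.

Measured so far in a functional assay on MCF7 cells (Homo sapiens) for antiproliferative activity, read by MTT assay, with a stated time of 72 h; a higher number here means a weaker inhibitor, a lower number a stronger inhibitor: compound 1 `O=C1COc2ccc(-c3cnc(Cl)c(NS(=O)(=O)c4ccc(F)cc4)c3)cc2N1C1CCCCC1`, > 40000 nM; compound 2 `COc1ncc(-c2ccc3c(c2)N(C2CCCCC2)C(=O)CO3)cc1NS(=O)(=O)c1ccc(F)cc1`, 30100 nM; compound 3 `COc1ccc(N2C(=O)COc3ccc(-c4cnc(OC)c(NS(=O)(=O)c5ccc(F)cc5)c4)cc32)cc1`, 8260 nM.

The value of compound 1 is a limit of the assay, not a number (the limit of > 40000 nM in this assay, at which 1 of the 3 values shown sits). Compound 2 and compound 1 differ by chloro in place of methoxy on an aromatic carbon, giving an at least 1.3-fold higher number from compound 2 to compound 1 (0.12 log units; that floor lies within the scatter). Compound 2 and compound 3 differ in their cores by 4-methoxyphenyl in place of cyclohexyl on an amide-type nitrogen in a ring, giving a 3.6-fold lower number from compound 2 to compound 3 (0.56 log units; beyond the scatter). Compound 4 `COc1ncc(-c2ccc3c(c2)N(c2ccc(Cl)cc2)C(=O)CO3)cc1NS(=O)(=O)c1ccc(F)cc1` is not yet measured in this assay. It differs from compound 3 by chloro in place of methoxy on an aromatic carbon, the same kind of change as from compound 2 to compound 1, but the place differs: a six-membered aromatic ring of carbon only rather than a ring with 1 nitrogen, next to the ring nitrogen and ortho to the ((4-fluorophenyl)sulfonyl)amino group. A step of about a 1.2-fold higher number from compound 3 to compound 4 (0.08 log units; within the scatter) is expected, resting on compound 2 and an at least 1.3-fold higher number from compound 2 to compound 1 (0.12 log units; that floor lies within the scatter). Compound 4 is estimated at 10000 nM, from 3000 nM to 30000 nM.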

Compound 4, half-maximal inhibitory concentration: 27600 nM
Compound 4: the middle estimate sits 2.8-fold (0.44 log units) below what was measured; measured number inside the range.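

Set side by side, chloro in place of methoxy on the two cores reads: the same change on two cores in this assay, an at least 1.3-fold higher number (0.12 log units; that floor lies within the scatter) from compound 2 to compound 1 and a 3.3-fold higher number (0.52 log units; beyond the scatter) from compound 3 to compound 4; the limit leaves it open whether they differ
In this assay compound 1 gives > 40000 nM, which is a limit and not a number.
The change gives a 3.3-fold higher number from compound 3 to compound 4 (0.52 log units; beyond the scatter), which shows a real step on that core but not that a step of this size carries over to the core of compound 2, and 4-chlorophenyl in place of cyclohexyl on the ring nitrogen gives a 1.1-fold lower number from compound 2 to compound 4 (0.04 log units; within the scatter).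

Still open, going by these compounds, is how an amine or a carboxylic acid in place of the chloro or methoxy group would read on either core. Also open, on these data alone, is whether a longer chain on the ring nitrogen would read differently from cyclohexyl and the substituted phenyl groups.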